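The compounds below may be only part of what the source reports. "The series", "measured", "known", "first", "only" and "open" are said of these compounds alone.

Measured compounds:
- compound 1, `CCC(C)c1cc(C=O)cc2cc(C(C)=O)c(=O)oc12`: 176000 nM
- compound 2, `CCC(C)c1cc(/C=C/C(=O)c2ccc(Cl)cc2)cc2cc(C(=O)OC)c(=O)oc12`: 28300 nM

Within the data shown here, only two compounds have been tested in a functional assay on KB cells (Homo sapiens) for cytotoxicity, read by sulforhodamine B assay, with a stated time of 48 h; a higher number here means a weaker inhibitor, a lower number a stronger inhibitor. Compound 1 has the higher of the two numbers, so it is the weaker of the pair, and the gap to compound 2 is beyond the usual scatter. Compound 2 differs from compound 1 in more than one place, so the two values say nothing about any single change on their own.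

The next compound to be measured is compound 3, `CCC(C)c1cc(C=O)cc2cc(C(=O)OC)c(=O)oc12`. It differs from compound 1 in one place: methoxy in place of methyl on a carbonyl carbon. Cut one bond further out, the same difference reads acetyl to methoxycarbonyl, on a carbonyl carbon whose other neighbour is an aromatic carbon.

Among the measured compounds shown here, nothing among the measured compounds isolates this change, so there is no step to lean on. A small change is expected, and the step of a 1.4-fold lower number from compound 1 to compound 3 (0.13 log units; within the scatter) is estimated to stay close to the scatter of this assay. Compound 3 is therefore expected to give about 130000 nM, with a range from 40000 nM to 400000 nM.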

Compound 3, half-maximal inhibitory concentration: 146000 nM
Beside the measured number, compound 3's estimate is 1.1-fold (0.05 log units) below it, within the range that was stated.
By their numbers in this assay, from the lowest: compound 2; then compounds 3 and 1 (each within the scatter of the next).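

Methoxy in place of methyl on this carbonyl carbon, which turns the acetyl into a methoxycarbonyl, can now be read as a single change, and in this assay it gives a 1.2-fold lower number from compound 1 to compound 3 (0.08 log units; within the scatter). This swap adds one heavy atom and brings in a hydrogen-bond acceptor, yet compound 1 and compound 3 cannot be told apart in this assay, so on the shared core the position accepts either group with no measurable shift in the number. Nothing available explains why the number holds steady, and no outside measurement bears on this result.

These two groups are close relatives, both attached through the same carbonyl carbon, so they sample only a narrow part of what this position could hold, and a carboxylic acid, an amide or a longer ester such as ethoxycarbonyl could behave quite differently. This is also a single pair on a single core, which leaves open whether the same swap would stay as quiet with a different group elsewhere on the molecule.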